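From Benzamido to tert-Butoxycarbonylamino on a Shared Core

A few compounds are considered here, and "the series" means these few. Any claim that something is new, unique, unknown or untested is made for them only; others in the source may bear on it.

Compound 1 `Cc1cc(C(=O)NCc2ccccn2)nn1Cc1cc(Cl)ccc1OCc1ccccc1`: 25.1 nM
Compound 2 `Cc1cc(NC(=O)C(C)C)nn1Cc1cc(Cl)ccc1OCc1ccccc1`: 25.1 nM
Compound 3 `Cc1cc(NC(=O)c2ccccc2)nn1Cc1cc(Cl)ccc1OCc1ccccc1`: 15.9 nM

In an assay on CHO-K1 cells for displacement of a labelled ligand from prostaglandin E2 receptor EP1 subtype (Homo sapiens) (on this read-out higher numbers stand for weaker inhibition and lower numbers for stronger inhibition), compound 3 gives the lowest of the three numbers, yet its gaps to compound 1 and compound 2 both sit within the scatter, so the three compounds cannot be placed in order on these data. Compound 4 `Cc1cc(NC(=O)OC(C)(C)C)nn1Cc1cc(Cl)ccc1OCc1ccccc1` has not yet been measured. It differs from compound 3 in one place: tert-butoxy in place of phenyl on a carbonyl carbon.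

The step that bears most directly on this change is a 1.6-fold lower number from compound 2 to compound 3 (0.20 log units; within the scatter), which is small and within the scatter, and which compound 4 in effect reverses by trading the phenyl for another non-aromatic group on the carbonyl carbon. The steps of no change at the digits printed from compound 1 to compound 2 (within the scatter) and a 1.6-fold lower number from compound 1 to compound 3 (0.20 log units; within the scatter) show the same flat picture across the whole set. The expected step is therefore a 1.6-fold higher number from compound 3 to compound 4 (0.20 log units; within the scatter), a change no larger than the scatter. For compound 4 the estimate is 25 nM, with a range from 10 nM to 63 nM.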

Compound 4, half-maximal inhibitory concentration: 25.1 nM
Compound 4: the middle estimate sits 1.0-fold (0.00 log units) below what was measured; low and high end bracket the measured number.
By their numbers in this assay, from the lowest: compounds 3, 1, 2 and 4 (each within the scatter of the next).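

In this assay the carbonyl carbon whose other neighbour is an amide-type nitrogen also accepts tert-butoxy, with its oxygen and no ring, and the step is a 1.6-fold higher number from compound 3 to compound 4 (0.20 log units; within the scatter) for the change from phenyl. Set against isopropyl on the same carbon, the result is no change at the digits printed from compound 2 to compound 4 (within the scatter) and set against the ((pyridin-2-yl)methyl)carbamoyl group on the aromatic carbon, it is no change at the digits printed from compound 1 to compound 4 (within the scatter) so the flat picture now extends to a group joined to the carbonyl carbon through oxygen. No measurement at hand gives a reason for this flatness.

Every step among the four compounds lies within the scatter, so they do not show which change at this place would move the number beyond it. From the compounds shown here alone, whether a longer chain on the carbonyl carbon or a carboxylic acid on the aromatic carbon would do so remains open.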